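A few compounds are considered here, and "the series" means these few. Any claim that something is new, unique, unknown or untested is made for them only; others in the source may bear on it.

Measured so far:
- compound 1 `Cc1ccc(C2=NN(C3=NC(c4ccccc4)CS3)C(c3cccc4ccccc34)C2)cc1`: 10400 nM
- compound 2 `O=C1CSC(N2N=C(c3ccc(Br)cc3)CC2c2cccc3ccccc23)=N1`: 13400 nM

In a functional assay on HepG2 cells (Homo sapiens) for inhibition, read by CCK-8 assay, with a stated time of 48 h (on this read-out lower numbers stand for stronger inhibition and higher numbers for weaker inhibition), compound 2 gives 13400 nM. This places it within the usual scatter of compound 1, which gives 10400 nM, so the two cannot be ranked against each other, and both numbers lie in the same range.

The next compound is compound 3 `Cc1ccc(C2=NN(C3=NC(=O)CS3)C(c3cccc4ccccc34)C2)cc1`. It departs from compound 2 at one place, methyl in place of bromo on an aromatic carbon, that is, 4-bromophenyl to 4-methylphenyl. The rest of the structure stays as it is.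

Among the measured compounds shown here, no pair of measured compounds shows this change on its own, so the data give no direct size for it. The expectation in this assay is therefore no step beyond the scatter, in either direction. The expected move is a 1.1-fold lower number from compound 2 to compound 3 (0.05 log units; within the scatter), an estimate that stays within the scatter. For compound 3 the estimated value is 12000 nM, with an expected range from 5000 nM to 30000 nM.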

Compound 3, half-maximal inhibitory concentration: 8660 nM
Compound 3: middle estimate off by 1.4-fold (0.14 log units), on the high side, within the range that was stated.
By their numbers in this assay, from the lowest: compounds 3, 1 and 2 (each within the scatter of the next).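

Methyl in place of bromo, 4-bromophenyl to 4-methylphenyl, now has a direct size in this assay: a 1.5-fold lower number from compound 2 to compound 3 (0.19 log units; within the scatter), so methyl and bromo cannot be ranked at this place on the aromatic ring. The group on the amine nitrogen in a ring can now also be read directly: exchanging the group of 11 heavy atoms for the group of 6 heavy atoms gives a 1.2-fold lower number from compound 1 to compound 3 (0.08 log units; within the scatter), and these two groups cannot be ranked either, although the exchange removes a six-membered aromatic ring of carbon only. No accompanying measurement bears on these results.

Still open, going by these compounds, is whether any group at the aromatic position, such as an amine, a carboxylic acid or a longer alkyl chain, would give a step beyond the scatter from compound 3 in this assay. The same question stands on the amine nitrogen in a ring, where a group carrying an amine or a carboxylic acid would extend a comparison that so far covers only the groups of compound 1 and compound 3.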